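Swapping the Side Chain for a Protected Amino Acid

This account rests on a few compounds, and the source may have more. Where it says the series, first, only, none or still open, it means among the compounds named here.

Measured so far in an assay for binding affinity to histamine H2 receptor (Homo sapiens); on this read-out higher numbers stand for weaker inhibition and lower numbers for stronger inhibition:
Compound 1, `NCCC(=O)N1CCN(CCCOc2ccc(C(=O)C3CC3)cc2)CC1`, gives 100000 nM.
Compound 2, `CN[C@@H](C(=O)N1CCN(CCCOc2ccc(C(=O)C3CC3)cc2)CC1)C(C)C`, gives 49000 nM.
Compound 3, `N[C@H](CC1CCCCC1)C(=O)N1CCN(CCCOc2ccc(C(=O)C3CC3)cc2)CC1`, gives 20400 nM.

Compound 3 stands lowest of the three numbers, with compound 2 nearest and compound 1 furthest, as shown by a 2.4-fold lower number from compound 2 to compound 3 (0.38 log units; beyond the scatter) and a 4.9-fold lower number from compound 1 to compound 3 (0.69 log units; beyond the scatter). Compound 4, `C[C@@H](NC(=O)OC(C)(C)C)C(=O)N1CCN(CCCOc2ccc(C(=O)C3CC3)cc2)CC1`, differs from compound 3 in one place: 1-((tert-butoxycarbonyl)amino)ethyl in place of 1-amino-2-cyclohexylethyl on a carbonyl carbon. All three measured steps change the side group on that same carbonyl carbon, and each was modest: a 2.0-fold lower number from compound 1 to compound 2 (0.31 log units; beyond the scatter), a 4.9-fold lower number from compound 1 to compound 3 (0.69 log units; beyond the scatter) and a 2.4-fold lower number from compound 2 to compound 3 (0.38 log units; beyond the scatter). None of them, however, trades a free amine for a carbamate, so they only loosely guide this step. Since every earlier swap moved the number modestly, a modest shift, or none beyond the scatter, is the likeliest outcome here too. Compound 4 is therefore expected to give 35000 nM, with a range from 10000 nM to 100000 nM. This expectation amounts to the step of a 1.7-fold higher number from compound 3 to compound 4 (0.23 log units; within the scatter), a modest move toward a higher number.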

Compound 4, inhibition constant: 83200 nM
Beside the measured number, compound 4's estimate is 2.4-fold (0.38 log units) below it, within the range that was stated.
By their numbers in this assay, from the lowest: compound 3; then compounds 2, 4 and 1 (each within the scatter of the next, the first and the last beyond it).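

In this assay, replacing the ring-bearing 1-amino-2-cyclohexylethyl group with the ring-free, carbamate-bearing 1-((tert-butoxycarbonyl)amino)ethyl group weakens inhibition (a 4.1-fold higher number from compound 3 to compound 4 (0.61 log units; beyond the scatter)). The same carbamate group, however, stays within the scatter of both ring-free amine side chains (a 1.7-fold higher number from compound 2 to compound 4 (0.23 log units; within the scatter); a 1.2-fold lower number from compound 1 to compound 4 (0.08 log units; within the scatter)), so at this position a carbamate is the first side chain shown without a free amine, yet it does not separate from compounds 1 and 2. No supporting measurement here accounts for these results.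

The compounds shown leave open whether the higher number in compound 4 follows the loss of the cyclohexyl ring or the arrival of the carbamate. A simple 1-aminoethyl group, or a cyclohexyl-bearing side chain with its amine protected as the same carbamate, would tell these two changes apart.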